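This account rests on a few compounds, and the source may have more. Where it says the series, first, only, none or still open, it means among the compounds named here.

Three compounds share one core and differ only in the group on the six-membered aromatic ring. Compound 1 `CS(=O)(=O)Nc1cccc2c1CCC2c1ncc[nH]1` carries a methanesulfonamido group, compound 2 `c1cc(-c2nccs2)c2c(c1)C(c1ncc[nH]1)CC2` a 1,3-thiazol-2-yl group, and compound 3 `c1cc(-c2cn[nH]c2)c2c(c1)C(c1ncc[nH]1)CC2` a 1H-pyrazol-4-yl group. In a functional assay on CHO cells for agonist activity at Alpha-1B adrenergic receptor (Homo sapiens), read by FLIPR and calcium flux (a higher number here means that more compound is needed for the effect, a lower number that less compound is needed), compound 1 reaches only the limit of > 10000 nM, not a number. Compound 2 likewise gives a limit of > 10000 nM. Compound 3 also stops at a limit of > 10000 nM. All three sit at the limit of > 10000 nM in this assay, at which 3 of the 3 values shown sit, so the steps a step that the two limits leave unreadable from compound 1 to compound 2, a step that the two limits leave unreadable from compound 1 to compound 3 and a step that the two limits leave unreadable from compound 2 to compound 3 cannot be sized; compound 3 stands at that limit with nothing to separate it from the other two.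

Compound 4 `CCS(=O)(=O)Nc1cccc2c1CCC2c1ncc[nH]1` awaits measurement. It differs from compound 3 by (ethylsulfonyl)amino in place of 1H-pyrazol-4-yl on an aromatic carbon. Among the measured compounds shown here, compound 4 thus most resembles compound 1, and no measured step gives a readable size to build on. The step that the limit leaves unreadable from compound 3 to compound 4 is expected to stay within the scatter, with no direction readable. Compound 4 is expected to give about 20000 nM, within 5000 nM to 100000 nM, most likely again as a limit.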

Compound 4, half-maximal effective concentration: > 10000 nM
Compound 4: a limit, no number (the forecaster's own chance of this, stated with the estimate: 85%); the middle value lies beyond the limit too.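

Compound 4 also stops at a limit, not a number, so its steps from compound 1, compound 2 and compound 3 cannot be read: the limit of > 10000 nM in this assay, at which 4 of the 4 values shown sit.

The compounds shown leave open how far apart these four lie in this assay, and whether any group on the shared core gives a readable value there.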